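The compounds below may be only part of what the source reports. "The series", "measured", "known", "first", "only" and "open" are said of these compounds alone.

Measured so far:
Compound 1 `CCCCOC(=O)CNC(=O)[C@H](CSc1ccc([N+](=O)[O-])cc1[N+](=O)[O-])NC(=O)CC[C@H](NC(=O)OC)C(=O)OCCCC`: > 300 uM (a limit)
Compound 2 `CCCCOC(=O)CNC(=O)[C@H](CSc1ccc([N+](=O)[O-])cc1[N+](=O)[O-])NC(=O)CC[C@H](NC(=O)OCc1ccccc1)C(=O)OCCCC`: 95.2 uM

In a toxicity assay on KB cells (Homo sapiens) for cytotoxicity, read by fluorescence, with a stated time of 3 days (on this read-out higher numbers stand for an effect only at larger amounts of compound and lower numbers for an effect already at smaller amounts), compound 1 gives > 300 uM, which is a limit of the assay and not a number. Compound 1 thus stands at the limit of > 300 uM in this assay, at which 1 of the 2 values shown sits. Compound 2, by contrast, gives a real number, 95.2 uM.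

The next structure is compound 3 `CCCCOC(=O)CNC(=O)[C@H](CSc1ccc([N+](=O)[O-])cc1[N+](=O)[O-])NC(=O)CC[C@H](NC(=O)CCc1c[nH]c2ccccc12)C(=O)OCCCC`, made from compound 1 by a single change: 2-(1H-indol-3-yl)ethyl in place of methoxy on a carbonyl carbon. In words, 2-(1H-indol-3-yl)ethyl comes in place of methoxy on a carbonyl carbon.

Within the data shown here, one measured step bears on this change, since it also extends the methoxy group and brings in an aromatic ring: an at least 3.1-fold lower number from compound 1 to compound 2 (0.49 log units; beyond the scatter). On the strength of that step by compound 2, a move to a lower number is expected for compound 3, of broadly similar size. That step kept the oxygen, whereas here the whole methoxy group leaves, so the expectation is loose.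

The expected change in this assay is an at least 4.2-fold lower number from compound 1 to compound 3 (0.63 log units; beyond the scatter).

For compound 3 the estimated value is 70 uM, with an expected range from 20 uM to 250 uM.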

Compound 3, concentration for half-maximal effect: 26 uM
Estimate against measurement, compound 3: 2.7-fold (0.43 log units) above, and the stated range covers the measured number.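

In this assay, putting 2-(1H-indol-3-yl)ethyl in place of methoxy on a carbonyl carbon gives an at least 11-fold lower number from compound 1 to compound 3 (1.06 log units; beyond the scatter), so the number can fall even when the whole methoxy group leaves, oxygen included, whereas the earlier step with benzyloxy kept that oxygen. Compound 1 carries a limit of the assay and not a number, so the size of that step is only a bound: the limit of > 300 uM in this assay, at which 1 of the 3 values shown sits. The comparison between two real numbers is the swap of benzyloxy for 2-(1H-indol-3-yl)ethyl on the same carbonyl carbon, which gives a 3.7-fold lower number from compound 2 to compound 3 (0.56 log units; beyond the scatter), showing that the number still depends on which group sits here when both groups carry an aromatic ring.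

Going by these compounds, how a plain 2-phenylethyl group would compare on this carbonyl carbon stays open, so the share of the five-membered aromatic ring with its nitrogen in these steps cannot be separated from that of the rest of the group. Also open, on these data alone, is how a chain ending in an amine or a carboxylic acid would read at this place in this assay.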